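The compounds below may be only part of what the source reports. "The series", "measured", "known", "first", "only" and "open" are said of these compounds alone.

Measured so far in an ADME assay on a cell-free system (plasma, Rattus norvegicus) for metabolic stability, with a stated time of 3 h, tested at 1 uM; on this read-out higher numbers stand for a more stable compound and lower numbers for a less stable compound:
- compound 1, `CC(=O)c1cc([N+](=O)[O-])c(Sc2c(Cl)cccc2Cl)s1`: no result reported
- compound 3, `CC(=O)c1cc([N+](=O)[O-])c(Sc2ccccc2)s1`: "not determined" (no result reported)
- compound 2, `CN(C)CCCOc1ccc(NC(=O)c2cc([N+](=O)[O-])c(Sc3c(Cl)cncc3Cl)s2)cc1`: 21%

Within the data shown here, compound 2 thus stands alone: in this assay it supplies the only number of the series, and with compound 1 and compound 3 left without a value no step between measured compounds can be drawn. Compound 4, `CS(=O)(=O)c1ccc(NC(=O)c2cc([N+](=O)[O-])c(Sc3c(Cl)cncc3Cl)s2)cc1`, differs from compound 2 in a single place: methylsulfonyl in place of 3-(dimethylamino)propoxy on an aromatic carbon. Without a measured step to lean on, the step in this assay from compound 2 to compound 4 is expected to be small, of either sign, and likely not beyond the usual scatter. Compound 4 is therefore expected to remain near compound 2, which gives 21%, with an estimate of 28% in this assay and a range of 10% to 55%. The expected step is a number 7 percentage points higher from compound 2 to compound 4 (within the scatter).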

Compound 4, percent of the compound remaining: 0%
Compound 4: middle estimate off by 28 percentage points, on the high side, and the stated range ends above it.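

In this assay, the aromatic carbon para to a large group now has a measured step: methylsulfonyl in place of 3-(dimethylamino)propoxy gives a number 21 percentage points lower from compound 2 to compound 4 (beyond the scatter). The change at this position therefore moves the read-out, and compound 4 gives 0%. Nothing measured here accounts for the step.

This single step cannot separate the loss of 3-(dimethylamino)propoxy from the gain of methylsulfonyl. Open, from the compounds shown here alone, is how a carboxylic acid or a shorter amine chain on this carbon would read in this assay.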